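Adding an Ethoxy Group: What Cytotoxicity Step to Expect

A few compounds are considered here, and "the series" means these few. Any claim that something is new, unique, unknown or untested is made for them only; others in the source may bear on it.

Three related compounds have been measured. Compound 1 `COc1ccc2c(=O)c(/C=C/C(=O)Nc3ccc(C)cc3)coc2c1` carries a methyl on an aromatic carbon, compound 2 `COc1ccc2c(=O)c(/C=C/C(=O)Nc3ccccc3)coc2c1` carries hydrogen in place of that methyl, and compound 3 `O=C(/C=C/c1coc2cc(O)ccc2c1=O)NCc1ccccc1` differs from both in more than one place. In an ADME assay on HepG2 2.2.15 cells (Homo sapiens) for cytotoxicity, read by MTT assay, with stated times of 48 h and 9 days (on this read-out lower numbers stand for higher toxicity in this test and higher numbers for lower toxicity in this test), compound 1 gives 979000 nM, compound 2 gives 523000 nM, and compound 3 gives 436000 nM. Compound 2 stands second highest of the three numbers, but its gap to each of the other two is within the scatter, so the three cannot be told apart here. Among the measured compounds shown here, the single measured step, a 1.9-fold lower number from compound 1 to compound 2 (0.27 log units; within the scatter), likewise stays within the scatter. Compound 4 `CCOc1ccc(NC(=O)/C=C/c2coc3cc(OC)ccc3c2=O)cc1` is related to compound 2 by ethoxy in place of hydrogen on an aromatic carbon. Like the methyl step, this swaps hydrogen for a small group on an aromatic carbon, and that step showed nothing beyond the scatter. Compound 4 is therefore expected to give 520000 nM in this assay, with a range from 250000 nM to 1000000 nM. The estimated step is a 1.0-fold lower number from compound 2 to compound 4 (0.00 log units; within the scatter), expected to remain within the scatter.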

Compound 4, half-maximal cytotoxic concentration: 460000 nM
Compound 4: middle estimate off by 1.1-fold (0.05 log units), on the high side; measured number inside the range.
By their numbers in this assay, from the lowest: compounds 3, 4, 2 and 1 (each within the scatter of the next, the first and the last beyond it).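

In this assay, the step of a 1.1-fold lower number from compound 2 to compound 4 (0.06 log units; within the scatter) shows that this place, para to a large group, takes ethoxy in place of hydrogen with no change that can be told from the scatter. Among the compounds shown here, the comparison of two groups at this place adds something new: the step of a 2.1-fold lower number from compound 1 to compound 4 (0.33 log units; beyond the scatter) is the first here to pass beyond the scatter, though only modestly. Compound 2, with hydrogen, lies within the scatter of both compound 1 and compound 4, so only the methyl and ethoxy compounds can be told apart.

The data offer no measured explanation for this gap. As far as these compounds go, an amine, a carboxylic acid or a longer chain at this place remains open, as does whether any such group would give a larger step.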